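A few compounds are considered here, and "the series" means these few. Any claim that something is new, unique, unknown or untested is made for them only; others in the source may bear on it.

Measured in an ADME assay on HEK293 cells (Homo sapiens) for cytotoxicity, read by MTT assay, with a stated time of 72 h; on this read-out lower numbers stand for stronger inhibition and higher numbers for weaker inhibition:
- Compound 1 `O=C(CN1CCN(C(=O)c2ccc(Br)cc2)CC1)N1CCN(CCCc2c[nH]c3ccc(F)cc23)CC1` gives 60500 nM
- Compound 2 `COc1cccc(C(=O)N2CCN(CC(=O)N3CCN(CCCc4c[nH]c5ccc(F)cc45)CC3)CC2)c1` gives 87100 nM
- Compound 3 `O=C(CN1CCN(C(=O)c2cccc(Br)c2)CC1)N1CCN(CCCc2c[nH]c3ccc(F)cc23)CC1` gives 40600 nM

Compound 1 sits in the middle of these three numbers, and neither of its two steps passes the scatter. Compound 4 `COc1ccc2[nH]cc(CCCN3CCN(C(=O)CN4CCN(C(=O)c5ccc(Br)cc5)CC4)CC3)c2c1` differs from compound 1 as follows: methoxy in place of fluoro on an aromatic carbon. Among the measured compounds shown here, no measured step touches that site. All three change the aryl group on the carbonyl carbon instead: a 1.4-fold higher number from compound 1 to compound 2 (0.16 log units; within the scatter), a 1.5-fold lower number from compound 1 to compound 3 (0.17 log units; within the scatter) and the modest 2.1-fold lower number from compound 2 to compound 3 (0.33 log units; beyond the scatter). These small steps offer only indirect guidance, so no clear shift is expected in this assay. The expected step is a 1.1-fold higher number from compound 1 to compound 4 (0.03 log units; within the scatter). For compound 4 the estimate is 65000 nM, with an expected range from 30000 nM to 130000 nM.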

Compound 4, half-maximal inhibitory concentration: 80500 nM
For compound 4 the middle estimate is 1.2-fold (0.09 log units) below the measured one, within the range that was stated.
By their numbers in this assay, from the lowest: compounds 3, 1, 4 and 2 (each within the scatter of the next, the first and the last beyond it).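

The change from 5-fluoro-1H-indol-3-yl to 5-methoxy-1H-indol-3-yl gives the only step shown at this site in this assay (a 1.3-fold higher number from compound 1 to compound 4 (0.12 log units; within the scatter)). With the 4-bromophenyl on the carbonyl carbon kept, this exchange on the six-membered aromatic ring stays within the scatter, as do the two aryl steps from compound 1. No measurement at hand explains this result. Going by these compounds, whether an amine or a carboxylic acid at this position would move the number remains open, as does whether methoxy there behaves alike when the 3-bromophenyl of compound 3 is present.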